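Replacing an Aromatic Amide Cap with a Saturated Ring

The compounds below may be only part of what the source reports. "The series", "measured", "known", "first", "only" and "open" are said of these compounds alone.

The measured compounds and their values in a physicochemical assay for solubility, read by HPLC; a lower number here means a less soluble compound, a higher number a more soluble compound:
Compound 1, `O=C(c1ccc(Cl)cc1)N1CCN(c2nc(=O)c3cc(C(F)(F)F)cc([N+](=O)[O-])c3s2)CC1`: 5.19 ug/mL
Compound 2, `CC(C)(C)C(=O)N1CCN(c2nc(=O)c3cc(C(F)(F)F)cc([N+](=O)[O-])c3s2)CC1`: 5.87 ug/mL
Compound 3, `O=C(c1cccc(F)c1)N1CCN(c2nc(=O)c3cc(C(F)(F)F)cc([N+](=O)[O-])c3s2)CC1`: 0.2 ug/mL

Compound 3 gives the lowest of the three numbers in this assay. Its nearest neighbour is compound 1, reached by a 26-fold lower number from compound 1 to compound 3 (1.41 log units; beyond the scatter), and its furthest is compound 2, reached by a 29-fold lower number from compound 2 to compound 3 (1.47 log units; beyond the scatter). Compound 1 and compound 2 sit within the scatter of each other, as shown by a 1.1-fold higher number from compound 1 to compound 2 (0.05 log units; within the scatter).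

Compound 4, `CC(C)(C)C1CCC(C(=O)N2CCN(c3nc(=O)c4cc(C(F)(F)F)cc([N+](=O)[O-])c4s3)CC2)CC1`, differs from compound 3 by 4-(tert-butyl)cyclohexyl in place of 3-fluorophenyl on a carbonyl carbon. Among the measured compounds shown here, two measured steps bear on this: the step from a tert-butyl cap to the 3-fluorophenyl cap, a 29-fold lower number from compound 2 to compound 3 (1.47 log units; beyond the scatter), and the step from a 4-chlorophenyl cap, a 26-fold lower number from compound 1 to compound 3 (1.41 log units; beyond the scatter). Both show that leaving the 3-fluorophenyl group for another cap carries a large rise. Since compound 4 carries a saturated ring bearing a tert-butyl group, recalling compound 2, a rise beyond the scatter is expected, though with only three points its size is uncertain. Compound 4 is therefore estimated at 2 ug/mL, between 0.4 ug/mL and 8 ug/mL, an expected step of a 10-fold higher number from compound 3 to compound 4 (1.00 log units; beyond the scatter).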

Compound 4, solubility: < 0.1 ug/mL
Compound 4 gave a limit, no number; the forecaster's own chance of this, stated with the estimate: 10%; middle value at least 20-fold (1.30 log units) away from the limit.
By their numbers in this assay, from the lowest: compound 3; then compounds 1 and 2 (each within the scatter of the next). At a limit, below all of these: compound 4.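

In this assay compound 4 gives a limit and not a number: the limit of < 0.1 ug/mL in this assay, at which 1 of the 4 values shown sits. The steps read an at least 58-fold lower number from compound 2 to compound 4 (1.76 log units; beyond the scatter) and an at least 51-fold lower number from compound 1 to compound 4 (1.71 log units; beyond the scatter), so carrying a tert-butyl group does not keep a cap with compound 2, and moving away from 3-fluorophenyl on this carbonyl carbon does not bring a rise in every case. The remaining step reads an at least 2.0-fold lower number from compound 3 to compound 4 (0.30 log units; that floor lies within the scatter), and since that floor lies within the scatter, compound 4 cannot yet be set apart from compound 3, which leaves the low end of this series holding one aromatic and one saturated ring.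

Still open, on these data alone, is whether the drop follows the cyclohexyl ring or the tert-butyl group on it, which an unsubstituted cyclohexyl cap would separate. Also open, as far as these compounds go, is what a cap bearing an amine or a carboxylic acid would give at this position.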